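Swapping one substituent, with an expected paw-edema value

The compounds below may be only part of what the source reports. "The series", "measured", "known", "first", "only" and "open" are said of these compounds alone.

Compound 1, `CCn1c(SCC(=O)Nc2ccc(C(C)=O)cc2)nnc1-c1ccc(OC)cc1`, gives 65% in a functional assay on the whole organism (strain albino) for inhibition, with Rattus norvegicus as the target, read by paw edema, with stated times of 30 min and 4 h, at a dose of 0.28 mmol/kg by the oral route; on this read-out lower numbers stand for less inhibition and higher numbers for more inhibition at the one dose given (going by the name of the read-out). Compound 2, `C=CCn1c(SCC(=O)Nc2ccc(/C(C)=N/O)cc2)nnc1-c1ccc(OC)cc1`, gives 75%.

Compound 2 stands highest of the two numbers, though compound 1 sits only a little lower, within the usual scatter. Compound 3, `C=CCn1c(SCC(=O)Nc2ccc(C(C)=O)cc2)nnc1-c1ccc(OC)cc1`, differs from compound 2 by a group of 3 heavy atoms (2 carbon, 1 oxygen; no ring) in place of a group of 4 heavy atoms (2 carbon, 1 nitrogen, 1 oxygen; no ring), on an aromatic carbon. Among the compounds with values here, no measured pair shows this step, so its size is not known from the data. Compound 1 carries the same acetyl group and gives 65% in this assay. On that basis the step is expected to be small, a number 7 percentage points lower from compound 2 to compound 3 (within the scatter), downward or none beyond the scatter. Compound 3 is therefore estimated to give 68%, between 55% and 80%.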

Compound 3, a percentage reported as inhibition, in the whole organism at one dose (the size of the read-out at that dose, not a potency): 68%
Beside the measured number, compound 3's estimate shows no gap at the digits printed; the measured number falls inside the stated range.
By their numbers in this assay, from the lowest: compounds 1, 3 and 2 (each within the scatter of the next).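

In this assay, acetyl in place of the group of 4 heavy atoms on the aromatic carbon gives a number 7 percentage points lower from compound 2 to compound 3 (within the scatter), and vinyl in place of methyl on the saturated chain carbon bound to an aromatic nitrogen gives a number 3 percentage points higher from compound 1 to compound 3 (within the scatter). Taken singly, neither change separates its pair at this one dose, which compounds 1 and 2, differing in more than one place, could not show. No evidence bears on these results. Still open, from the compounds shown here alone, is whether an amine or a carboxylic acid on that aromatic carbon, or a longer chain in place of vinyl, would give a step beyond the scatter.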